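Adding a 4-Methylphenyl to the Chloro Analogue

The compounds below may be only part of what the source reports. "The series", "measured", "known", "first", "only" and "open" are said of these compounds alone.

Of the compounds shown here, three have been measured in a functional assay on A549 cells (Homo sapiens) for antiproliferative activity, read by MTT assay, with a stated time of 72 h; a lower number here means a stronger inhibitor, a higher number a weaker inhibitor: compound 1 `COc1ncc(-c2ccc3c(c2)N(c2ccc(C)cc2)C(=O)CO3)cc1NS(=O)(=O)c1ccc(F)cc1` gives 5870 nM, and compound 2 `COc1ncc(-c2ccc3c(c2)NC(=O)CO3)cc1NS(=O)(=O)c1ccc(F)cc1` gives 8070 nM. For compound 3 `O=C1COc2ccc(-c3cnc(Cl)c(NS(=O)(=O)c4ccc(F)cc4)c3)cc2N1` this assay reports > 40000 nM, which is a limit of the assay and not a number (the limit of > 40000 nM in this assay, at which 1 of the 3 values shown sits).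

Compound 1 and compound 2 share a core and differ in one place: 4-methylphenyl in place of hydrogen on an amide-type nitrogen in a ring. That change gave a 1.4-fold lower number from compound 2 to compound 1 (0.14 log units; within the scatter), so the two are effectively equal. Compound 2 and compound 3 differ in the core itself: chloro in place of methoxy on an aromatic carbon, and that step was an at least 4.9-fold higher number from compound 2 to compound 3 (0.69 log units; beyond the scatter).

Compound 4 `Cc1ccc(N2C(=O)COc3ccc(-c4cnc(Cl)c(NS(=O)(=O)c5ccc(F)cc5)c4)cc32)cc1` has not been measured. It is related to compound 3 exactly as compound 1 is to compound 2: 4-methylphenyl in place of hydrogen on an amide-type nitrogen in a ring. The place lines of the two changes read the same word for word, so this is the same kind of change on a different core. Since the earlier instance stayed within the scatter, the step of a number no higher from compound 3 to compound 4 (the limit leaves the size open) is expected to be small as well. Compound 4 is therefore estimated at 40000 nM, with a likely range from 15000 nM to 110000 nM, and a limit rather than a number is quite possible.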

Compound 4, half-maximal inhibitory concentration: 30900 nM
For compound 4 the middle estimate is 1.3-fold (0.11 log units) above the measured one; measured number inside the range.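

In this assay, placing 4-methylphenyl on the amide-type nitrogen of the chloro compound gave an at least 1.2-fold lower number from compound 3 to compound 4 (0.11 log units; that floor lies within the scatter), and the comparison with the methoxy core reads: the same change on two cores in this assay, a 1.4-fold lower number (0.14 log units; within the scatter) from compound 2 to compound 1 and an at least 1.2-fold lower number (0.11 log units; that floor lies within the scatter) from compound 3 to compound 4; the limit leaves it open whether they differ

Chloro in place of methoxy, now with 4-methylphenyl present, gave a 5.3-fold higher number from compound 1 to compound 4 (0.72 log units; beyond the scatter), and the two instances of that change compare as follows: the same change on two cores in this assay, an at least 4.9-fold higher number (0.69 log units; beyond the scatter) from compound 2 to compound 3 and a 5.3-fold higher number (0.72 log units; beyond the scatter) from compound 1 to compound 4; the limit leaves it open whether they differ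

Compound 3 stands at a limit and not at a number, so the 4-methylphenyl step on the chloro core may be larger than its floor, and the data do not show that it carries over at the same size: the limit of > 40000 nM in this assay, at which 1 of the 4 values shown sits.

The compounds shown carry only hydrogen or 4-methylphenyl on the amide-type nitrogen, so it stays open how a benzyl group or a longer chain ending in an amine would behave there. Only methoxy and chloro appear on the aromatic carbon, which leaves open whether an ethoxy group or a nitrile would give numbers closer to the methoxy or the chloro compounds.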